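The source may hold more compounds than are shown below. What is called first, only, known or untested is meant among the compounds shown, and "the series" means these compounds.

Measured compounds in this set:
- compound 1 `O=C(Nc1ccc(Cl)cc1CN1C(=O)c2ccccc2C1=O)C1CCCCC1`; limit of the assay: < 1000 nM
- compound 2 `O=C(Nc1ccc(Br)cc1CN1C(=O)c2ccccc2C1=O)c1ccccn1`; limit of the assay: < 1000 nM
- compound 3 `O=C(Nc1ccc(Cl)cc1CN1C(=O)c2ccccc2C1=O)c1ccccc1`; limit of the assay: < 1000 nM

In an assay on CHO cells for positive allosteric modulation of metabotropic glutamate receptor 5 (Rattus norvegicus), read by FLIPR (on this read-out higher numbers stand for an effect only at larger amounts of compound and lower numbers for an effect already at smaller amounts), compound 3 gives < 1000 nM, a limit of the assay and not a number. Compound 1 likewise gives only a limit, < 1000 nM. Compound 2 too gives only a limit, < 1000 nM. Among the measured compounds shown here, because of the limit of < 1000 nM in this assay, at which 3 of the 3 values shown sit, the one measured step that touches compound 3, a step that the two limits leave unreadable from compound 1 to compound 3, cannot be read in size or direction; it shows only that both ends sit beyond the same limit.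

Compound 4 `O=C(Nc1ccc(Cl)cc1CN1C(=O)c2ccccc2C1=O)c1cccnn1` differs from compound 3 in a single place: pyridazin-3-yl in place of phenyl on a carbonyl carbon. For the measured compounds named here, no measured step in this set covers that change, so the expectation rests on the limits alone. Compound 4 is expected to land in this assay at about 300 nM, estimated within 60 nM to 1500 nM. The step this estimate implies is a step that the limit leaves unreadable from compound 3 to compound 4, an expectation rather than a reading, with a fair chance that the assay again returns only a limit.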

Compound 4, half-maximal effective concentration: < 1000 nM
Compound 4 gave a limit, no number; the forecaster's own chance of this, stated with the estimate: 60%; the middle value is on the limit's open side.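

No step between compound 1, compound 3 and compound 4 can be read in size or direction in this assay, because the values give limits and no numbers: the limit of < 1000 nM in this assay, at which 4 of the 4 values shown sit.

The compounds shown leave open whether cyclohexyl, phenyl and pyridazin-3-yl on the carbonyl carbon differ at all in this read-out.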